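Series notes: chloro to hydrogen at the aromatic carbon

The source may report more compounds than this note shows. Statements on the series, on what has been measured and on what is new or still open speak of the compounds shown alone.

Among the measured compounds shown here, the series so far holds two measured compounds. Compound 1 `O=C(/C=C/c1cccc([N+](=O)[O-])c1)c1ccc2ccccc2c1` carries a nitro on the aromatic ring; in a functional assay on L1210 cells (Mus musculus) for cytotoxicity, read by MTT assay, with a stated time of 24 h (a lower number here means a stronger inhibitor, a higher number a weaker inhibitor), compound 1 gives 24000 nM. Compound 2 `O=C(/C=C/c1cccc(Cl)c1)c1ccc2ccccc2c1` has chloro in its place, and in this assay compound 2 gives 38000 nM. For the measured compounds named here, the one recorded step, a 1.6-fold higher number from compound 1 to compound 2 (0.20 log units; within the scatter), does not separate the two. Going by the values given here, compound 2 thus stands at one end of the two numbers, with compound 1 as its only neighbour, and the gap between them lies within the scatter.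

Compound 3 `O=C(/C=C/c1ccccc1)c1ccc2ccccc2c1` is not yet measured. Relative to compound 2 the change is hydrogen in place of chloro on an aromatic carbon. Among the compounds with values here, the only step that bears on it is a 1.6-fold higher number from compound 1 to compound 2 (0.20 log units; within the scatter), a swap of one substituent for another at the same aromatic carbon, and it was small. Within the data shown here, removing the substituent altogether is a change of the same kind; no step has moved the number beyond the scatter, so none beyond the scatter is expected here either, with at most a slight drift upward. For compound 3 in this assay the estimate is 45000 nM, between 18000 nM and 110000 nM, which means an expected step of a 1.2-fold higher number from compound 2 to compound 3 (0.07 log units; within the scatter).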

Compound 3, half-maximal inhibitory concentration: 37000 nM
Compound 3: middle estimate off by 1.2-fold (0.09 log units), on the high side; the range from low to high includes it.
By their numbers in this assay, from the lowest: compounds 1, 3 and 2 (each within the scatter of the next).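

With hydrogen now at this aromatic carbon, the series has a reference without a substituent, and in this assay the change from 3-chlorophenyl to phenyl reads as a 1.0-fold lower number from compound 2 to compound 3 (0.01 log units; within the scatter). The comparison with the nitro compound reads the same way, as a 1.5-fold higher number from compound 1 to compound 3 (0.19 log units; within the scatter), so neither chloro nor nitro at this place can be told apart from hydrogen, and the two earlier compounds alone could not show that. Across these three compounds, a substituent on this aromatic carbon is therefore not needed to reach numbers of this size, and neither of the two substituents shown separates from the unsubstituted compound; no measurement at hand bears on why the numbers stay together at this place.

The compounds shown leave open whether a group of a different kind at this carbon, such as an amine, a carboxylic acid or a methoxy group, would move the number beyond the scatter. They also leave open whether this flat reading holds at other carbons of the same ring or with a change in the shared core, since every compound here differs only at this one place.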